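The compounds below may be only part of what the source reports. "The series", "measured", "known", "first", "only" and "open" are said of these compounds alone.

Compound 1, `C=C(CC)C(=O)c1ccc(OCC(=O)NC(CS)C(=O)OCC)c(Cl)c1Cl`, was tested in a functional assay on CLL cells (Homo sapiens) for cytotoxicity, read by MTT assay, with a stated time of 48 h (a higher number here means that more compound is needed for the effect, a lower number that less compound is needed), and gives 4800 nM. Its companion compound 2, `C=C(CC)C(=O)c1ccc(OCC(=O)Nc2ccc3c(C)cc(=O)oc3c2)c(Cl)c1Cl`, gives 2800 nM in this assay. These two numbers lie within the usual scatter of repeated measurements, so compound 1 stands together with compound 2 rather than apart from it. Among the measured compounds shown here, no step between measured compounds that differ in a single place is available, so the effect of any one change has to be judged afresh. Compound 3, `C=C(CC)C(=O)c1ccc(OCC(=O)Nc2ccc(C(N)=O)cc2)c(Cl)c1Cl`, differs from compound 1 by one exchange: 4-carbamoylphenyl in place of 1-(ethoxycarbonyl)-2-sulfanylethyl on an amide-type nitrogen. For the measured compounds named here, with no measured single-point step to rest on, and with compound 2 giving 2800 nM after a different replacement on the amide-type nitrogen, the expected step is a 1.4-fold lower number from compound 1 to compound 3 (0.14 log units; within the scatter), no larger than the scatter, in no firm direction. Compound 3 is estimated to give 3500 nM in this assay, with a range from 1500 nM to 9000 nM.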

Compound 3, half-maximal effective concentration: 3700 nM
The estimate for compound 3 lay 1.1-fold (0.02 log units) below the measured number; measured number inside the range.
By their numbers in this assay, from the lowest: compounds 2, 3 and 1 (each within the scatter of the next).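

In this assay, among the compounds shown here, the first comparison of two compounds that differ only on the amide-type nitrogen gives a 1.3-fold lower number from compound 1 to compound 3 (0.11 log units; within the scatter) for this exchange. An open chain, 1-(ethoxycarbonyl)-2-sulfanylethyl, and 4-carbamoylphenyl, which carries a six-membered aromatic ring, are therefore not told apart by this assay, despite the difference in their make-up. No measurement available here offers an explanation for this result.

From the compounds shown here alone, it remains open whether any replacement at this nitrogen can shift the number beyond the scatter, since this single step does not. Also unresolved is how a plain hexyl chain, or a phenyl ring carrying a carboxylic acid or an amine in place of the carbamoyl group, would compare.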